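Acrylamide side-chain amine on the shared quinazoline-free core series

The source may hold more compounds than are shown below. What is called first, only, known or untested is meant among the compounds shown, and "the series" means these compounds.

Measured compounds, read in a functional assay on PC-3 cells (Homo sapiens) for antiproliferative activity, read by MTT assay, with a stated time of 72 h; on this read-out higher numbers stand for weaker inhibition and lower numbers for stronger inhibition:
compound 1 `CC/C=C/C(=O)Nc1cc2c(N3CCc4ccccc43)ncnc2cc1OC` gives 5890 nM
compound 2 `C/C=C/C(=O)Nc1cc2c(N3CCCc4ccccc43)ncnc2cc1OC` gives 7520 nM
compound 3 `C/C=C/C(=O)Nc1cc2c(N3CCCc4ccccc43)ncnc2cc1O[C@@H]1CCOC1` gives 9350 nM

Compound 2 sits second highest of the three numbers. Among the compounds with values here, its nearest neighbour is compound 3, and the only single-site step so far, a 1.2-fold higher number from compound 2 to compound 3 (0.09 log units; within the scatter), concerns the oxygen substituent on the aromatic ring, not the amide chain. Compound 1 and compound 2 differ in the chain and in the saturated ring of the core at once, so their two values can only be set side by side; they lie close to each other.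

Compound 4 `COc1cc2ncnc(N3CCCc4ccccc43)c2cc1NC(=O)/C=C/CN(C)C` is the next compound to be read. It differs from compound 2 by dimethylamino in place of hydrogen on a saturated chain carbon bound to a double-bonded chain carbon. Within the data shown here, no measured step touches this position, so nothing so far bears directly on it; the one step in hand, at a different site, stayed within the scatter. The change is therefore expected to give, if anything, a small step in this assay , and the estimated shift from compound 2 to compound 4 is a 1.5-fold lower number from compound 2 to compound 4 (0.18 log units; within the scatter). For compound 4 the expected value is 5000 nM, with a range from 1500 nM to 15000 nM.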

Compound 4, half-maximal inhibitory concentration: 1750 nM
Compound 4: middle estimate off by 2.9-fold (0.46 log units), on the high side; low and high end bracket the measured number.
By their numbers in this assay, from the lowest: compound 4; then compounds 1, 2 and 3 (each within the scatter of the next).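

In this assay, within the data shown here, the saturated chain carbon bound to a double-bonded chain carbon is the first site where a single change moves the number beyond the scatter. Dimethylamino in place of hydrogen there gives a 4.3-fold lower number from compound 2 to compound 4 (0.63 log units; beyond the scatter), a modest step, while the one earlier step, a 1.2-fold higher number from compound 2 to compound 3 (0.09 log units; within the scatter), at the oxygen on the aromatic ring, stayed within the scatter. This effect of the chain position rests on a single pair, and nothing at hand bears on the origin of the step.

The compounds shown leave open whether the step belongs to dimethylamino in particular or would also appear with another amine, such as diethylamino or a primary amine, with a carboxylic acid at the same carbon, or with a longer chain carrying the amine. They also leave open whether dimethylamino on the chain gives a step of similar size when the oxygen on the aromatic ring carries oxolan-3-yl, as in compound 3, or on the core of compound 1.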